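Swapping a Ring Substituent on a Shared Core

The source may hold more compounds than are shown below. What is called first, only, known or untested is meant among the compounds shown, and "the series" means these compounds.

Measured compounds:
compound 1 `COc1ccc2[nH]c(C(=O)N3CC(=O)N(Cc4ccccc4)[C@@H](CN4CCCCC4)C3)cc2c1`: 0.283 h
compound 2 `COc1ccc2[nH]c(C(=O)N3CC(=O)N(Cc4ccc[nH]4)[C@@H](Cc4ccccc4)C3)cc2c1`: 0.267 h
compound 3 `COc1cccc(CN2C(=O)CN(C(=O)c3cc4cc(OC)ccc4[nH]3)C[C@@H]2c2ccccc2)c1`: 0.118 h

All three compounds were tested in an ADME assay on microsomes from liver (Homo sapiens) for metabolic stability, with a stated time of 30 min, tested at 1 uM; on this read-out higher numbers stand for a longer-lived compound and lower numbers for a shorter-lived compound. Compound 1 gives the highest of the three numbers, but compound 2 sits within the usual scatter of it, so the two cannot be told apart on this read-out; only compound 3 lies clearly lower than compound 1. All three numbers describe short-lived compounds.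

Compound 4 `COc1ccc2[nH]c(C(=O)N3CC(=O)N(Cc4ccccc4)[C@@H](N4CCc5ccccc54)C3)cc2c1` has not yet been measured. It keeps the shared core of compound 1 and differs from it in one place: 2,3-dihydro-1H-indol-1-yl in place of (piperidin-1-yl)methyl on a saturated ring carbon. Going by the values given here, no measured pair in this set changes a group at that position, so there is no directly comparable step to lean on. Because compound 1 gives 0.283 h and every compound shown here is short-lived, compound 4 is expected to remain in the same region, with the step from compound 1 to compound 4 estimated as a 1.3-fold lower number from compound 1 to compound 4 (0.11 log units; within the scatter), most likely not beyond the scatter. The estimate for compound 4 in this assay is 0.22 h, with a range from 0.1 h to 0.5 h.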

Compound 4, half-life: 0.25 h
Compound 4: middle estimate off by 1.1-fold (0.06 log units), on the low side; low and high end bracket the measured number.
By their numbers in this assay, from the lowest: compound 3; then compounds 4, 2 and 1 (each within the scatter of the next).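

Going by these compounds alone, this is the first step seen at this saturated ring carbon, next to the ring nitrogen. Replacing (piperidin-1-yl)methyl with 2,3-dihydro-1H-indol-1-yl gives a 1.1-fold lower number from compound 1 to compound 4 (0.05 log units; within the scatter) in this assay and so leaves no readable change in half-life, even though the entering group brings a six-membered aromatic ring of carbon only and more heavy atoms, and the leaving group's one-carbon link to the core is gone. No supporting measurement is available to explain this outcome.

Within the data shown here, this single pair shows only that one swap left the half-life where it was and that both compounds remain short-lived. It leaves open whether a very different group on this carbon, such as a carboxylic acid, a primary amine or a plain methyl, would move the half-life beyond the scatter.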